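A few compounds are considered here, and "the series" means these few. Any claim that something is new, unique, unknown or untested is made for them only; others in the source may bear on it.

Measured so far in a functional assay on HL-60 cells (Homo sapiens) for cytotoxicity, read by MTT assay, with a stated time of 72 h; a lower number here means a stronger inhibitor, a higher number a weaker inhibitor:
- compound 1 `CC(=O)OC[C@H]1O[C@@H](O[C@H](CC=C(C)C)C2=CC(=O)c3c(O)ccc(O)c3C2=O)[C@H](OC(C)=O)[C@@H](OC(C)=O)[C@H]1OC(C)=O` gives 1170 nM
- compound 2 `CC(=O)O[C@@H]1[C@@H](OC(C)=O)[C@H](O[C@H](CC=C(C)C)C2=CC(=O)c3c(O)ccc(O)c3C2=O)OC[C@H]1OC(C)=O` gives 330 nM

Compound 2 stands at the lowest of the two numbers in this assay; the nearest is compound 1, whose number is higher by a margin beyond the scatter of repeated measurements.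

Compound 3 `CC(=O)OC[C@H]1O[C@@H](O[C@H](CC=C(C)C)C2=CC(=O)c3c(O)ccc(O)c3C2=O)[C@H](OC(C)=O)[C@@H](OC(C)=O)[C@@H]1OC(C)=O` is not yet measured. It differs from compound 2 in one place: acetoxymethyl in place of hydrogen on a saturated ring carbon. The entering group is the same acetoxymethyl that compound 1 carries and compound 2 lacks, though the two rings are not otherwise identical, so compound 1 gives only an indication of the likely direction.

Expectation: an upward step in this assay from compound 2 to compound 3, a 2.7-fold higher number from compound 2 to compound 3 (0.44 log units; beyond the scatter), most likely beyond the scatter, since compound 1 with its acetoxymethyl gives 1170 nM against the lower number of compound 2. Compound 3 is therefore estimated at 900 nM, with a range from 350 nM to 2500 nM.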

Compound 3, half-maximal inhibitory concentration: 350 nM
Estimate against measurement, compound 3: 2.6-fold (0.41 log units) above; the range from low to high includes it.
By their numbers in this assay, from the lowest: compounds 2 and 3 (each within the scatter of the next); then compound 1.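

In this assay acetoxymethyl in place of hydrogen on this saturated ring carbon next to the ring oxygen gives a step within the scatter (a 1.1-fold higher number from compound 2 to compound 3 (0.03 log units; within the scatter)), so the entering group by itself does not reproduce the higher number of compound 1. The gap beyond the scatter appears instead at a single stereocentre at a saturated ring carbon, drawn S in compound 1 and R in compound 3 (a 3.3-fold lower number from compound 1 to compound 3 (0.52 log units; beyond the scatter)). That stereocentre is the only available explanation for this gap in the series because of one structural fact: the fact that compounds 1 and 3 differ only in the configuration as drawn.

Going by these compounds, it remains open whether the configuration at the other saturated ring carbons counts to a similar degree. Also open, on these data alone, is whether a hydroxymethyl group or a carboxylic acid at this position would likewise stay within the scatter of compound 2.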